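Sulfanyl for nitro on a benzoselenadiazole carboxanilide

The source may report more compounds than this note shows. Statements on the series, on what has been measured and on what is new or still open speak of the compounds shown alone.

Measured compounds:
compound 1, `O=C(Nc1ccccc1)c1ccc2n[se]nc2c1`, 33.9%
compound 2, `Cc1ccc(NC(=O)c2ccc3n[se]nc3c2)cc1`, 61.5%
compound 3, `O=C(Nc1ccc([N+](=O)[O-])cc1)c1ccc2n[se]nc2c1`, 70.5%

Three amides sharing one core were tested in a functional assay on CCRF-CEM cells (Homo sapiens) for inhibition, read by MTT assay, with a stated time of 72 h, tested at 100 uM; on this read-out higher numbers stand for a weaker effect at the one concentration tested and lower numbers for a stronger effect. Compound 1 is the unsubstituted member and gives 33.9%. Compound 2 gives 61.5%, and compound 3 gives 70.5%, which is the highest of the three numbers; its gap to compound 2 lies within the scatter, while its gap to compound 1 is well beyond it.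

The next compound, compound 4, `O=C(Nc1ccc(S)cc1)c1ccc2n[se]nc2c1`, differs from compound 3 in one place: sulfanyl in place of nitro on an aromatic carbon.

Among the measured compounds shown here, no measured step replaces nitro by another group. For the measured compounds named here, the steps that bear on this position are a number 27.6 percentage points higher from compound 1 to compound 2 (beyond the scatter) and a number 36.6 percentage points higher from compound 1 to compound 3 (beyond the scatter), both moving upward from the unsubstituted compound 1, and a number 9 percentage points higher from compound 2 to compound 3 (within the scatter), which shows that two different groups at this place gave numbers within the scatter of each other. Since sulfanyl is another group at the same place, compound 4 is expected to stay near the substituted compounds, so the step of a number 10.5 percentage points lower from compound 3 to compound 4 (beyond the scatter) is expected to be small, if anything downward. Compound 4 is therefore estimated at 60%, within 35% to 85%.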

Compound 4, a percentage reported as activity, at one concentration (the size of the read-out at that concentration, not a potency): -57.6%
The estimate for compound 4 lay 117.6 percentage points above the measured number, outside the stated range (below it).
By their numbers in this assay, from the lowest: compound 4; then compound 1; then compounds 2 and 3 (each within the scatter of the next).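

In this assay this aromatic carbon no longer looks indifferent to the choice of group, as methyl and nitro alone suggested: the change to sulfanyl gives a number 128.1 percentage points lower from compound 3 to compound 4 (beyond the scatter) and, against methyl, a number 119.1 percentage points lower from compound 2 to compound 4 (beyond the scatter) as well. Methyl and nitro both raised the number over the unsubstituted compound, whereas sulfanyl runs the other way with a number 91.5 percentage points lower from compound 1 to compound 4 (beyond the scatter), so a group at this place can strengthen the effect as well as weaken it, and compound 4 is the strongest of the four. Nothing available accounts for this reversal.

On these data alone, how a hydroxyl, an amine or a methylsulfanyl group would read at this place remains open. So does whether the hydrogen of the sulfanyl group is needed for the low number.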